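The compounds below may be only part of what the source reports. "The series", "measured", "known", "first", "only" and "open" are said of these compounds alone.

Compound 1 `COc1ccc(SCc2ccc(/C=C/C(=O)Nc3ccccc3N)cc2)cc1OC` gives 21.9%
Compound 2 `Cc1ccc(SCc2ccc(/C=C/C(=O)Nc3ccccc3N)cc2)cc1` gives 21.7%

In a functional assay on HeLa cells (Homo sapiens) for inhibition, read by CCK-8 assay, with a stated time of 72 h, tested at 8 uM (a higher number here means more inhibition of growth at the concentration tested, a lower number less inhibition of growth), compound 1 stands level with compound 2, as the two numbers lie within the scatter of each other. Compound 3 `Nc1ccccc1NC(=O)/C=C/c1ccc(CSc2ccc(F)cc2)cc1` has not been measured yet. It differs from compound 1 by 4-fluorophenyl in place of 3,4-dimethoxyphenyl on a sulfur in the group on the sulfur, with 4-fluorophenyl in place of 3,4-dimethoxyphenyl. Among the measured compounds shown here, the one measured step that bears on this is a number 0.2 percentage points lower from compound 1 to compound 2 (within the scatter) and it also removes 3,4-dimethoxyphenyl, putting 4-methylphenyl there instead. One step is thin evidence, but no change beyond the scatter is expected in this assay here. The estimated change is a number 1.1 percentage points higher from compound 1 to compound 3 (within the scatter) and so stays small. The estimated value for compound 3 is 23% with a range from 12% to 38% when measured.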

Compound 3, percent growth inhibition at one concentration: 10.4%
Compound 3: middle estimate off by 12.6 percentage points, on the high side; measured number outside the range, below it.
By their numbers in this assay, from the lowest: compound 3; then compounds 2 and 1 (each within the scatter of the next).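

In this assay, the group on the sulfur proves able to change the result: 4-fluorophenyl in place of 3,4-dimethoxyphenyl gives a number 11.5 percentage points lower from compound 1 to compound 3 (beyond the scatter). Fluoro in place of methyl on an aromatic carbon gives a number 11.3 percentage points lower from compound 2 to compound 3 (beyond the scatter), so this small exchange separates two compounds even though 3,4-dimethoxyphenyl and 4-methylphenyl stand level. No measurement at hand accounts for this loss of growth inhibition. Going by these compounds, it remains open whether chloro or methoxy in place of the fluoro of compound 3 would match the fluoro or the methyl result.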